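A few compounds are considered here, and "the series" means these few. Any claim that something is new, unique, unknown or untested is made for them only; others in the source may bear on it.

Compound 1: `OCC#CCSc1cnc2ccccc2c1SCC#CCBr` gives 36.2 ug/mL in a functional assay on SW707 cells (Homo sapiens) for cytotoxicity, read by sulforhodamine B assay, with a stated time of 72 h; a lower number here means a stronger inhibitor, a higher number a weaker inhibitor.
Compound 2: `C[Se]c1c(SCC#CCO)cnc2ccccc12` gives 3.5 ug/mL in this assay.

Among the measured compounds shown here, of the two compounds measured so far, compound 2 stands with the lowest number, and its only neighbour, compound 1, sits a large distance away: a 10-fold lower number from compound 1 to compound 2 (1.01 log units; beyond the scatter). That single step is the whole record of this series, and it concerns a different exchange from the one at hand, since it swapped a group of six heavy atoms for a group of two.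

Compound 3, `COc1c(SCC#CCO)cnc2ccccc12`, has not yet been measured. Compared with compound 2 it carries one change, (a group of 2 heavy atoms (1 carbon, 1 oxygen; no ring) in place of a group of 2 heavy atoms (1 carbon, 1 selenium; no ring), on an aromatic carbon). For the measured compounds named here, no measured pair shows what happens when a carbon-selenium group gives way to a methoxy group at this position, so the one recorded step offers no direct guide to the size or direction of the effect. With nothing in the data pointing either way, the expectation is a step that stays within the scatter, with the real uncertainty lying in both directions.

Compound 3 is therefore estimated at 6 ug/mL, with a range from 2 ug/mL to 20 ug/mL, meaning an expected step of a 1.7-fold higher number from compound 2 to compound 3 (0.23 log units; within the scatter).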

Compound 3, concentration for 50% inhibition: 67.4 ug/mL
Beside the measured number, compound 3's estimate is 11-fold (1.05 log units) below it, and the stated range ends below it.
By their numbers in this assay, from the lowest: compound 2; then compounds 1 and 3 (each within the scatter of the next).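

At this aromatic carbon, opposite the ring nitrogen, the identity of a small group matters greatly in this assay: replacing the group of carbon and selenium with methoxy gives a 19-fold higher number from compound 2 to compound 3 (1.28 log units; beyond the scatter), although both groups hold the same number of heavy atoms. The earlier step could be read as a matter of swapping a larger group for a smaller one, but this pair shows that a small group at this position does not by itself bring a low number, and the other new step, a 1.9-fold higher number from compound 1 to compound 3 (0.27 log units; within the scatter), stays within the scatter, so methoxy and the larger sulfur-containing group of compound 1 cannot be told apart here. Nothing available explains why the selenium-containing group and methoxy give such different numbers.

The compounds shown leave open whether the low number of compound 2 depends on selenium itself or would also appear with a methylthio group, in which sulfur takes selenium's place. They also leave open how an amine or a longer chain such as ethoxy would behave at this position.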